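This account rests on a few compounds, and the source may have more. Where it says the series, first, only, none or still open, it means among the compounds named here.

Measured so far:
compound 1 `Cc1ccc(-c2ccc(C(=O)N=C(N)N)cc2S(C)(=O)=O)cc1` — 100 nM
compound 2 `CSc1cc(C)c(C(=O)N=C(N)N)cc1S(C)(=O)=O` — 6 nM
compound 3 `CCc1cc(OC)c(S(C)(=O)=O)cc1C(=O)N=C(N)N` — 30 nM

In a functional assay for inhibition of sodium/hydrogen exchanger (Oryctolagus cuniculus) (a lower number here means a stronger inhibitor, a higher number a weaker inhibitor), compound 2 gives 6 nM, the lowest of the three numbers, and its gaps to compound 3 and compound 1 both lie beyond the scatter, so it is the strongest inhibitor shown here. Compound 4 `Cc1cc(OC(C)(C)C)c(S(C)(=O)=O)cc1C(=O)N=C(N)N` is not yet measured. It differs from compound 2 by tert-butoxy in place of methylsulfanyl on an aromatic carbon. Among the compounds with values here, no pair of measured compounds differs by exactly this change, so there is no measured step to lean on. Compound 3, which carries a methoxy group and gives 30 nM, hints that an oxygen-linked group at this place may cost some potency. Compound 4 is therefore expected to be a somewhat weaker inhibitor, with a step of a 3.3-fold higher number from compound 2 to compound 4 (0.52 log units; beyond the scatter) in this assay, giving an estimated 20 nM, within 5 nM to 80 nM.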

Compound 4, half-maximal inhibitory concentration: 9.4 nM
The estimate for compound 4 lay 2.1-fold (0.33 log units) above the measured number, and the stated range covers the measured number.
By their numbers in this assay, from the lowest: compounds 2 and 4 (each within the scatter of the next); then compound 3; then compound 1.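

In this assay, putting tert-butoxy in place of methylsulfanyl gives a 1.6-fold higher number from compound 2 to compound 4 (0.19 log units; within the scatter) and so leaves the two compounds indistinguishable. Within the data shown here, at this position, ortho to a methylsulfonyl group, a larger oxygen-linked group of 5 heavy atoms and a sulfur-linked group of 2 heavy atoms thus read alike, something the earlier compounds could not show. No available evidence bears on this result. Going by these compounds, it remains open how an amine or a carboxylic acid would read at this position, and whether a longer chain or a ring would also read alike.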